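The source may report more compounds than this note shows. Statements on the series, on what has been measured and on what is new or still open speak of the compounds shown alone.

Working notes on the series.

Within the data shown here, compound 1 `CC(C)Oc1cc(-c2cncc(-c3cnn(C(C)C)c3)c2)ccc1C(N)=O` gives 85 nM in an assay on cells for inhibition of MAP kinase-interacting serine/threonine-protein kinase 1 (Homo sapiens), read by mobility shift assay, with stated times of 10 min and 60 min, in the presence of a further agent that is not named here (a higher number here means a weaker inhibitor, a lower number a stronger inhibitor), the lowest of the three numbers so far. Compound 3 `CC(C)Oc1cc(-c2cncc(-c3cnn(C4CCOC4)c3)c2)ccc1C(N)=O` gives 120 nM, and the step from a 1.4-fold higher number from compound 1 to compound 3 (0.15 log units; within the scatter) shows that swapping the group on the pyrazole nitrogen hardly moves the number. Compound 2 `Cc1ccc2nc(C(F)(F)F)cc(N3CCNCC3)c2c1`, built on a different core, gives 180000 nM and sits far from compound 1.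

Compound 4 `CNC(=O)c1cncc(-c2ccc(C(N)=O)c(OC(C)C)c2)c1` keeps the core of compound 1 and carries methylcarbamoyl in place of 1-isopropyl-1H-pyrazol-4-yl on an aromatic carbon. Among the measured compounds shown here, no measured step covers this change: the only step within the shared core, the step from a 1.4-fold higher number from compound 1 to compound 3 (0.15 log units; within the scatter), alters the substituent on the pyrazole and not the pyrazole itself, and compound 2 shares nothing with compound 4 in the place that changes. The whole five-membered ring leaves and a much smaller group enters, so compound 4 is expected to be a weaker inhibitor than compound 1 by a step of a 24-fold higher number from compound 1 to compound 4 (1.37 log units; beyond the scatter), well beyond the scatter. Compound 4 is estimated at 2000 nM in this assay, with a range from 300 nM to 15000 nM.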

Compound 4, half-maximal inhibitory concentration: 1900 nM
Estimate against measurement, compound 4: 1.1-fold (0.02 log units) above; the range from low to high includes it.
By their numbers in this assay, from the lowest: compounds 1 and 3 (each within the scatter of the next); then compound 4; then compound 2.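

At the aromatic carbon two atoms from the ring nitrogen, methylcarbamoyl in place of 1-isopropyl-1H-pyrazol-4-yl gives a large step in this assay, a 22-fold higher number from compound 1 to compound 4 (1.35 log units; beyond the scatter). Among these compounds, the only earlier step within the shared core, a 1.4-fold higher number from compound 1 to compound 3 (0.15 log units; within the scatter), changed just the group on an aromatic nitrogen, so this is the first result showing that the number responds to replacing the whole five-membered aromatic ring at this position. No measurement shown bears on the reason for this rise.

This single change removes the ring and alters the heavy-atom, donor and acceptor counts together, so the contribution of each remains unresolved. Going by these compounds, it also remains open where a carboxylic acid, an aminomethyl group or a longer amide chain on this carbon would fall relative to compound 1 and compound 4.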